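Chloro in Place of Fluoro on a Shared Core

The source may report more compounds than this note shows. Statements on the series, on what has been measured and on what is new or still open speak of the compounds shown alone.

compound 1 `COc1ccc(-c2noc(-c3cc4cc(OC)ccc4[nH]3)n2)cc1`: > 50000 nM
compound 2 `COc1ccc(-c2noc(-c3cc4cc(F)ccc4[nH]3)n2)cc1`: > 50000 nM

In a functional assay on MCF7 cells (Homo sapiens) for antiproliferative activity, read by WST assay, with a stated time of 72 h (on this read-out lower numbers stand for stronger inhibition and higher numbers for weaker inhibition), compound 1 gives only a limit of the assay, > 50000 nM. In this assay compound 2 likewise gives only a limit, > 50000 nM. The step that the two limits leave unreadable from compound 1 to compound 2 cannot be sized from two limits. Compound 2 therefore stands at the limit where every value shown sits, (the limit of > 50000 nM in this assay, at which 2 of the 2 values shown sit).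

Compound 3, `COc1ccc(-c2noc(-c3cc4cc(Cl)ccc4[nH]3)n2)cc1`, differs from compound 2 by chloro in place of fluoro on an aromatic carbon. Among the compounds with values here, the only measured step, from compound 1 to compound 2, concerns a different exchange and is itself unreadable, so no sized step speaks to the change leading to compound 3. No value shown reaches a number. Compound 3 is therefore expected to give again only a limit in this assay, with an expected step that the limit leaves unreadable from compound 2 to compound 3. The estimate for compound 3 is 70000 nM, within a range from 20000 nM to 250000 nM.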

Compound 3, half-maximal inhibitory concentration: > 50000 nM
Compound 3: a limit, no number; the forecaster's own chance of this, stated with the estimate: 85%; the middle value is on the limit's open side.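

In this assay compound 3 gives only a limit of the assay, > 50000 nM. Its steps from compound 1 and from compound 2 therefore cannot be read. The compounds shown leave open whether methoxy, fluoro and chloro at this place differ at all in this assay.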